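Benzyloxy amide series: dichlorobenzyl swap on the methyl analogue

This account rests on a few compounds, and the source may have more. Where it says the series, first, only, none or still open, it means among the compounds named here.

Three compounds have numbers in an ADME assay on HEK-293T cells (Homo sapiens) for antiproliferative activity, read by MTT assay, with a stated time of 48 h, in the presence of a further agent that is not named here; on this read-out lower numbers stand for higher toxicity in this test and higher numbers for lower toxicity in this test. Compound 1 `O=C(NOCc1ccccc1F)c1cn(-c2ccccc2)nc1-c1ccccc1` gives 75700 nM. Compound 2 `O=C(NOCc1ccc(Cl)cc1Cl)c1cn(-c2ccccc2)nc1-c1ccccc1` gives 40200 nM. Compound 3 `Cc1ccc(-c2nn(-c3ccccc3)cc2C(=O)NOCc2ccccc2F)cc1` gives 20600 nM, the lowest of the three numbers, although its gap to compound 2 lies within the scatter; against compound 1 the step is a 3.7-fold lower number from compound 1 to compound 3 (0.57 log units; beyond the scatter). Compound 4 `Cc1ccc(-c2nn(-c3ccccc3)cc2C(=O)NOCc2ccc(Cl)cc2Cl)cc1` differs from compound 3 by 2,4-dichlorophenyl in place of 2-fluorophenyl on a saturated chain carbon bound to an oxygen. For the measured compounds named here, the one measured step that bears on this change is a 1.9-fold lower number from compound 1 to compound 2 (0.27 log units; within the scatter), which stayed within the scatter. Applied to compound 3, the expected step in this assay is therefore a 1.7-fold lower number from compound 3 to compound 4 (0.23 log units; within the scatter), a drift to a lower number that need not exceed the scatter. Compound 4 is estimated at 12000 nM, with a range from 5000 nM to 30000 nM.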

Compound 4, half-maximal cytotoxic concentration: 39600 nM
Beside the measured number, compound 4's estimate is 3.3-fold (0.52 log units) below it; the whole stated range lies below it.
By their numbers in this assay, from the lowest: compounds 3, 4, 2 and 1 (each within the scatter of the next, the first and the last beyond it).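

In this assay the swap of 2-fluorophenyl for 2,4-dichlorophenyl on the methyl core gives a 1.9-fold higher number from compound 3 to compound 4 (0.28 log units; within the scatter), while the methyl change on the 2,4-dichlorophenyl compounds gives a 1.0-fold lower number from compound 2 to compound 4 (0.01 log units; within the scatter). The swap therefore does not carry over as one constant step between the two cores: the same change on two cores in this assay, a 1.9-fold lower number (0.27 log units; within the scatter) from compound 1 to compound 2 and a 1.9-fold higher number (0.28 log units; within the scatter) from compound 3 to compound 4, 3.6-fold (0.56 log units) apart, beyond the scatter of two such steps
The methyl change likewise differs with the group on the saturated chain carbon bound to an oxygen: the same change on two cores in this assay, a 3.7-fold lower number (0.57 log units; beyond the scatter) from compound 1 to compound 3 and a 1.0-fold lower number (0.01 log units; within the scatter) from compound 2 to compound 4, 3.6-fold (0.56 log units) apart, beyond the scatter of two such steps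

The compounds shown do not tell what lies behind this gap. From the compounds shown here alone, whether an amine or a longer chain on that carbon would follow the step of either core also stays open.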